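Swapping an indole for a hydroxyphenyl on a shared core

The compounds below may be only part of what the source reports. "The series", "measured", "known", "first", "only" and "open" are said of these compounds alone.

Compound 2 `CC(C)N(Cc1cccc(OCCCCCC(=O)O)c1)C(=O)c1ccc(-c2ccc3[nH]ccc3c2)cc1` was tested in an ADME assay on Raji cells (Homo sapiens) for cytotoxicity, read by CellTiter-Glo and resazurin assay, with a stated time of 72 h; on this read-out higher numbers stand for an effect only at larger amounts of compound and lower numbers for an effect already at smaller amounts. In this assay compound 2 gives > 26000 nM, which is a limit of the assay rather than a number. Compound 1 `CC(C)Oc1cccc(-c2ccc(C(=O)N(Cc3cccc(OCCCCCC(=O)O)c3)C(C)C)cc2)c1` differs from compound 2 only at one aromatic carbon. In this assay compound 1 gives > 26000 nM, also a limit. The step that the two limits leave unreadable from compound 1 to compound 2 cannot be sized, and the limit of > 26000 nM in this assay, at which 2 of the 2 values shown sit, shows that both measured values sit at the same limit. Compound 3 `CC(C)N(Cc1cccc(OCCCCCC(=O)O)c1)C(=O)c1ccc(-c2cccc(O)c2)cc1` carries 3-hydroxyphenyl in place of 1H-indol-5-yl on an aromatic carbon. Among the measured compounds shown here, the only measured step is unreadable, and no measured step sizes this change. The expected step is a step that the limit leaves unreadable from compound 2 to compound 3, nothing readable beyond the scatter, with compound 3 most likely again at the limit. The estimate for compound 3 in this assay is 40000 nM, in a range from 20000 nM to 80000 nM.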

Compound 3, half-maximal effective concentration: > 26000 nM
Compound 3: only a limit was reported; the forecaster's own chance of this, stated with the estimate: 85%; the middle value does not contradict the limit.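

Among the compounds shown here, compound 3 also gives only a limit, so no step among compound 1, compound 2 and compound 3 can be read: the limit of > 26000 nM in this assay, at which 3 of the 3 values shown sit. The compounds shown leave open how the 3-isopropoxyphenyl, 1H-indol-5-yl and 3-hydroxyphenyl groups on the shared core compare.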